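Shortening the ether side chain to an aminocyclohexyl ring

The compounds below may be only part of what the source reports. "The series", "measured", "known", "first", "only" and "open" are said of these compounds alone.

Compound 1 `NCCCOc1ccc([C@H]2CC[C@]3(CC2)OOC2(O3)C3CC4CC(C3)CC2C4)cc1` gives < 7 mL.min-1.g-1 in an ADME assay on microsomes from liver (Rattus norvegicus) for metabolic stability, read by LC-MS, tested at 1 uM (on this read-out lower numbers stand for slow clearance and higher numbers for fast clearance), which is a limit of the assay rather than a number.
Compound 2 `c1cc([C@H]2CC[C@]3(CC2)OOC2(O3)C3CC4CC(C3)CC2C4)ccc1OCCC1CCNCC1` gives 9 mL.min-1.g-1 in this assay.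
Compound 3 `c1cc([C@H]2CC[C@]3(CC2)OOC2(O3)C3CC4CC(C3)CC2C4)ccc1OC1CCNCC1` gives 21 mL.min-1.g-1 in this assay.

Of the two plain numbers, compound 2 has the lower one; compound 3 shows a 2.3-fold higher number from compound 2 to compound 3 (0.37 log units; beyond the scatter). Compound 4 `N[C@H]1CC[C@@H](Oc2ccc([C@H]3CC[C@]4(CC3)OOC3(O4)C4CC5CC(C4)CC3C5)cc2)CC1` differs from compound 2 by 4-aminocyclohexyl in place of 2-(piperidin-4-yl)ethyl on an oxygen on an aromatic ring. The most relevant measured step is the one where 2-(piperidin-4-yl)ethyl gives way to piperidin-4-yl, a 2.3-fold higher number from compound 2 to compound 3 (0.37 log units; beyond the scatter), and the same direction appears in an at least 3.0-fold higher number from compound 1 to compound 3 (0.47 log units; beyond the scatter). Compound 4 also puts a saturated ring straight on the aromatic oxygen, so a modest rise in clearance is expected, roughly a 1.7-fold higher number from compound 2 to compound 4 (0.22 log units; within the scatter). Compound 4 is therefore estimated at 15 mL.min-1.g-1, most likely between 7 mL.min-1.g-1 and 35 mL.min-1.g-1.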

Compound 4, intrinsic clearance in microsomes: < 7 mL.min-1.g-1
Compound 4: a limit, no number (the forecaster's own chance of this, stated with the estimate: 10%); middle value at least 2.1-fold (0.33 log units) away from the limit.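

A saturated ring on the aromatic oxygen does not by itself bring a higher number in this assay, as 4-aminocyclohexyl in place of piperidin-4-yl gives an at least 3.0-fold lower number from compound 3 to compound 4 (0.47 log units; beyond the scatter) in the same place. Against the longer 2-(piperidin-4-yl)ethyl group, the change gives an at least 1.2-fold lower number from compound 2 to compound 4 (0.10 log units; that floor lies within the scatter) and so shows no clear drop. Compound 4 gives a limit, not a number: the limit of < 7 mL.min-1.g-1 in this assay, at which 2 of the 4 values shown sit.

The step from compound 1 to compound 4 cannot be read. Going by these compounds, whether a morpholine ring or a carboxylic acid on the same oxygen would also reach this limit stays open.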